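Chain extension between carbonyl and tetrazole in the series

The source may hold more compounds than are shown below. What is called first, only, known or untested is meant among the compounds shown, and "the series" means these compounds.

Measured compounds:
- compound 1, `CCCc1c(COc2ccc(C(=O)Cc3nnn[nH]3)cc2)ccc(C(C)=O)c1O`: 24.1 mg/kg
- compound 2, `CCCc1c(COc2ccc(C(=O)CCCC(=O)O)cc2)ccc(C(C)=O)c1O`: 9.5 mg/kg
- compound 3, `CCc1c(COc2ccc(C(=O)CC(C)(C)Cc3nnn[nH]3)cc2)ccc(C(C)=O)c1O`: 1.1 mg/kg

In an in vivo functional assay on the whole organism (Rattus norvegicus) with cysteinyl leukotriene receptor (Homo sapiens) as the target (a lower number here means that less compound is needed, a higher number that more compound is needed for the effect), compound 1 gives the highest number of the three; compound 2 lies nearest and compound 3 furthest below it. Among the compounds with values here, the only single-point step measured so far, a 2.5-fold lower number from compound 1 to compound 2 (0.40 log units; beyond the scatter), exchanges the acidic group directly on the chain carbon and is modest in size.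

Compound 4, `CCCc1c(COc2ccc(C(=O)CC(C)(C)Cc3nnn[nH]3)cc2)ccc(C(C)=O)c1O`, is the unmeasured analogue. 1-((1H-tetrazol-5-yl)methyl)-1-methylethyl in place of 1H-tetrazol-5-yl on a saturated chain carbon bound to a carbonyl carbon The step from compound 1 to compound 2 bears on this only loosely, since it swaps the acidic group rather than lengthening the chain. More telling is compound 3, which carries the same 1-((1H-tetrazol-5-yl)methyl)-1-methylethyl chain on an ethyl-bearing core and gives 1.1 mg/kg against 24.1 mg/kg for compound 1, although no single-point step between them is counted. Compound 4 is therefore expected to fall well below compound 1, at roughly the level of compound 3. The estimate for compound 4 is 1.5 mg/kg, with a range of 0.6 mg/kg to 4 mg/kg, and the expected step of a 16-fold lower number from compound 1 to compound 4 (1.21 log units; beyond the scatter).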

Compound 4, dose for half-maximal effect: 1.3 mg/kg
Beside the measured number, compound 4's estimate is 1.2-fold (0.06 log units) above it; low and high end bracket the measured number.
By their numbers in this assay, from the lowest: compounds 3 and 4 (each within the scatter of the next); then compound 2; then compound 1.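

In this assay the step to the longer, branched chain is large (a 19-fold lower number from compound 1 to compound 4 (1.27 log units; beyond the scatter)) on an unchanged core, so the place described as a saturated chain carbon bound to a carbonyl carbon responds strongly to what is attached there. The same chain also outdoes 2-carboxyethyl, with a 7.3-fold lower number from compound 2 to compound 4 (0.86 log units; beyond the scatter) on the same core, a modest step but one that exceeds the step seen earlier between the two shorter groups (a 2.5-fold lower number from compound 1 to compound 2 (0.40 log units; beyond the scatter)). With this chain in place, the methyl added two bonds along the chain from an aromatic carbon leaves the number unchanged (a 1.2-fold higher number from compound 3 to compound 4 (0.07 log units; within the scatter)), and no data bearing on the reason for any of these steps are available.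

An unbranched chain ending in 1H-tetrazol-5-yl would show whether the step belongs to chain length or to the branching. A carboxylic acid on the same branched chain would show how far the result depends on the tetrazole.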